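A few compounds are considered here, and "the series" means these few. Any claim that something is new, unique, unknown or untested is made for them only; others in the source may bear on it.

Working notes on the series sharing one core, each member carrying a carboxymethyl group, as followed in an in vitro functional assay on HEK285-7 cells for antagonist activity at prostaglandin D2 receptor 2 (Homo sapiens), read by BRET and beta-arrestin recruitment; on this read-out higher numbers stand for weaker inhibition and lower numbers for stronger inhibition. Compound 1 `Cc1nc(-c2ccc(Cl)cc2)c(CC(=O)O)s1` gives 41000 nM in this assay. Compound 2 `CCC(c1ccccc1)c1nc(-c2ccc(Cl)cc2)c(CC(=O)O)s1` reaches only a limit of the assay, > 100000 nM, and no number; this is the limit of > 100000 nM in this assay, at which 1 of the 3 values shown sits. Compound 3 `N#Cc1ccc(-c2nc(C(c3ccc(F)cc3)c3ccc(F)cc3)sc2CC(=O)O)cc1` gives 1500 nM in this assay, the lowest of the two numbers shown, with compound 1 the nearest at a clearly higher value, a gap beyond the usual scatter. Among the compounds with values here, no pair among the measured compounds differs in a single place, so no measured step is available to calibrate the next change.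

Compound 4 `Cc1cc(-c2nc(C(c3ccc(F)cc3)c3ccc(F)cc3)sc2CC(=O)O)ccn1` is not yet measured. It differs from compound 3 by 2-methylpyridin-4-yl in place of 4-cyanophenyl on an aromatic carbon. Starting from compound 3 at 1500 nM, a step of modest size toward a higher number, or none beyond the scatter, is expected for a 2.0-fold higher number from compound 3 to compound 4 (0.30 log units; within the scatter). Compound 4 is estimated at 3000 nM in this assay, with a range from 800 nM to 12000 nM.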

Compound 4, half-maximal inhibitory concentration: 53 nM
The estimate for compound 4 lay 57-fold (1.75 log units) above the measured number; the measured number lies below the stated range.
By their numbers in this assay, from the lowest: compound 4; then compound 3; then compound 1. At a limit, above all of these: compound 2.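

Within the data shown here, on the aromatic carbon next to the ring nitrogen, 2-methylpyridin-4-yl in place of 4-cyanophenyl gives a 28-fold lower number from compound 3 to compound 4 (1.45 log units; beyond the scatter) in this assay, the first measured single-place step and one well beyond the scatter. This position is therefore not indifferent to the group it carries, even though both groups hold 0 hydrogen-bond donors and 1 hydrogen-bond acceptor and neither has a net charge, so these counts do not separate them. No measured property shown here bears on this step.

The compounds shown do not tell whether the step follows the ring nitrogen or the methyl; pyridin-4-yl, or an amino or methoxy group in place of the methyl, would separate the two. From the compounds shown here alone, whether 2-methylpyridin-4-yl gives a similar step alongside other groups on the shared core also stays open.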